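This account rests on a few compounds, and the source may have more. Where it says the series, first, only, none or still open, it means among the compounds named here.

Compound 1 `Cn1ccc2c(Oc3ccc(NC(=O)c4cn(-c5ccc(Br)cc5)c5ccccc5c4=O)cc3F)ccnc21` gives 1260 nM in a functional assay on HepG2 cells (Homo sapiens) for inhibition, read by MTT assay, with a stated time of 72 h; on this read-out higher numbers stand for weaker inhibition and lower numbers for stronger inhibition. Compound 3 `COc1ccc(-n2cc(C(=O)Nc3ccc(Oc4ccnc5c4ccn5C)c(F)c3)c(=O)c3ccccc32)cc1` carries a methoxy where compound 1 carries a bromo; in this assay compound 3 gives 3750 nM. The step of a 3.0-fold higher number from compound 1 to compound 3 (0.47 log units; beyond the scatter) is the only one measured in this series. Compound 2 `Cn1ccc2c(Oc3ccc(NC(=O)c4cn(-c5ccc(F)c(Cl)c5)c5ccccc5c4=O)cc3F)ccnc21` gives "not determined" (no result reported) in this assay, so there is no number to place it against compounds 1 and 3. Compound 4 `O=C(Nc1ccc(Oc2ccnc3[nH]ccc23)c(F)c1)c1cn(-c2ccc(F)c(Cl)c2)c2ccccc2c1=O` differs from compound 2 only by hydrogen in place of methyl on an aromatic nitrogen. Among the measured compounds shown here, the one measured step concerns a different part of the molecule, the substituent on the aromatic ring attached to the nitrogen, so it gives no guide to this change. Compound 4 is therefore expected to land near the range spanned by compounds 1 and 3, at an estimated 1800 nM with a range from 400 nM to 8000 nM.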

Compound 4, half-maximal inhibitory concentration: 3390 nM
Estimate against measurement, compound 4: 1.9-fold (0.27 log units) below; low and high end bracket the measured number.
By their numbers in this assay, from the lowest: compound 1; then compounds 4 and 3 (each within the scatter of the next).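

Among the compounds shown here, compound 4 yields no new step: its only one-place partner, compound 2, has no number to compare. The effect of hydrogen in place of methyl on the aromatic nitrogen stays open, and no supporting evidence is available to explain it.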